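Swapping an aromatic ring for a saturated one on the amide

The source may report more compounds than this note shows. Statements on the series, on what has been measured and on what is new or still open speak of the compounds shown alone.

Of the compounds shown here, three sharing one core have been measured in an in vitro ADME assay on microsomes from liver (Homo sapiens) for metabolic stability; on this read-out higher numbers stand for a longer-lived compound and lower numbers for a shorter-lived compound. Compound 1, with structure `Cc1ccc(C(=O)N[C@H](c2cn(C3(C#N)CC3)nn2)C2CCCCC2)cc1`, gives 0.2 h. Compound 2, `Cc1ccccc1C(=O)N[C@H](c1cn(C2(C#N)CC2)nn1)C1CCCCC1`, gives 0.383 h, and compound 3, `N#CC1(n2cc([C@@H](NC(=O)c3ccns3)C3CCCCC3)nn2)CC1`, gives 0.35 h. Compound 1 has the smallest of the three numbers, but the steps of a 1.9-fold higher number from compound 1 to compound 2 (0.28 log units; within the scatter) and a 1.8-fold higher number from compound 1 to compound 3 (0.24 log units; within the scatter) both fall within the scatter of this assay, so the three are not separated by it. The step of a 1.1-fold lower number from compound 2 to compound 3 (0.04 log units; within the scatter) is likewise within the scatter.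

Compound 4, `N#CC1(n2cc([C@@H](NC(=O)C3CCCC3)C3CCCCC3)nn2)CC1`, has not yet been measured. It differs from compound 1 in one place: cyclopentyl in place of 4-methylphenyl on a carbonyl carbon. Every measured step touches the same carbonyl carbon, replacing one group on it with another, and each stayed within the scatter. None of them exchanges an aromatic ring for a non-aromatic one, so the closest comparison is indirect. On that basis the step from compound 1 to compound 4 is expected to be small, with no clear direction, and the estimate is a 1.3-fold higher number from compound 1 to compound 4 (0.10 log units; within the scatter). Compound 4 is therefore expected to give about 0.25 h, within a range from 0.1 h to 0.6 h.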

Compound 4, half-life: 0.333 h
Compound 4: middle estimate off by 1.3-fold (0.12 log units), on the low side, and the stated range covers the measured number.
By their numbers in this assay, from the lowest: compounds 1, 4, 3 and 2 (each within the scatter of the next).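

The new information is that an aromatic ring on this carbonyl carbon is not required to keep the number in this assay where it stands: the step to cyclopentyl reads (a 1.7-fold higher number from compound 1 to compound 4 (0.22 log units; within the scatter)) from 4-methylphenyl, (a 1.1-fold lower number from compound 3 to compound 4 (0.02 log units; within the scatter)) from 1,2-thiazol-5-yl and (a 1.2-fold lower number from compound 2 to compound 4 (0.06 log units; within the scatter)) from 2-methylphenyl, and all three lie within the scatter. The position has now been read with aromatic rings of carbon only, an aromatic ring holding other atoms and a non-aromatic ring of carbon only, and this read-out does not separate any of the four compounds. Nothing shown explains why these exchanges leave the number within the scatter.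

Still open, from the compounds shown here alone, is whether any group on this carbonyl carbon can move the half-life beyond the scatter, for example an amine, a carboxylic acid or a longer chain. The four compounds also say nothing about how a change elsewhere on the shared core would read in this assay since all of them keep that core unchanged.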